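Benzyl in place of ethyl on a weakly active core

The source may hold more compounds than are shown below. What is called first, only, known or untested is meant among the compounds shown, and "the series" means these compounds.

Compound 1, `CCCc1nc(C)c2c(C)nn(CC)c(=O)n12`, was tested in a functional assay for inhibition, with Homo sapiens as the target; on this read-out higher numbers stand for weaker inhibition and lower numbers for stronger inhibition. In this assay compound 1 gives only a limit, > 48000 nM. Compound 2, `CCCc1nc(C)c2cnn(CC)c(=O)n12`, differs from it by hydrogen in place of methyl on an aromatic carbon. In this assay compound 2 likewise reaches only a limit, > 48000 nM. The step that the two limits leave unreadable from compound 1 to compound 2 therefore cannot be sized, because of the limit of > 48000 nM in this assay, at which 2 of the 2 values shown sit. Compound 3, `CCCc1nc(C)c2c(C)nn(Cc3ccccc3)c(=O)n12`, carries a larger change: phenyl in place of methyl on a saturated chain carbon bound to an aromatic nitrogen. Within the data shown here, no measured step bears on this change in a readable way; both measured values sit at the limit, and no direction can be drawn from them. Compound 3 is estimated at 60000 nM, within 10000 nM to 300000 nM, with a limit again the most likely report in this assay. The step that the limit leaves unreadable from compound 1 to compound 3 is expected to stay within the scatter, with no readable gain or loss.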

Compound 3, half-maximal inhibitory concentration: > 48000 nM
Compound 3: a limit, no number; the forecaster's own chance of this, stated with the estimate: 75%; the middle value does not contradict the limit.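

Compound 1 and compound 3 both give only a limit in this assay, so no size can be read for the change from ethyl to benzyl: the limit of > 48000 nM in this assay, at which 3 of the 3 values shown sit. The compounds shown leave open whether any change to the shared core brings inhibition that can be given as a number.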